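A Phenyl at the End of the Amide Chain

A few compounds are considered here, and "the series" means these few. Any claim that something is new, unique, unknown or untested is made for them only; others in the source may bear on it.

In a toxicity assay on THP-1 cells (Homo sapiens) for inhibition (on this read-out lower numbers stand for higher toxicity in this test and higher numbers for lower toxicity in this test), compound 1 `COc1ccc(-c2nc3ncc(-c4ccc(F)cc4)cc3[nH]2)cc1` gives > 100000 nM, which is a limit and not a number. Compound 2 `CCCC(=O)Nc1ncc(-c2ccc(OC)cc2)n1C` gives > 100000 nM, which is also a limit. Compound 2 thus stands, with compound 1, at the limit of > 100000 nM in this assay, at which 2 of the 2 values shown sit.

Compound 3 `COc1ccc(-c2cnc(NC(=O)CCc3ccccc3)n2C)cc1` has not yet been measured. It differs from compound 2 by phenyl in place of methyl on a saturated chain carbon, two bonds along the chain from a carbonyl carbon. The same difference, cut one bond further out, reads propyl to phenethyl.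

Among the measured compounds shown here, no measured pair of compounds shows what such a change does in this assay, so the expectation rests only on compound 2 with its > 100000 nM. Compound 3 may well stay at that limit, and any shift is expected to run toward lower numbers, meaning higher toxicity in this test. The estimated step is an at least 1.4-fold lower number from compound 2 to compound 3 (0.15 log units; that floor lies within the scatter), a modest one if it appears at all. For compound 3 the estimate is 70000 nM, with an expected range of 25000 nM to 100000 nM.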

Compound 3, half-maximal cytotoxic concentration: > 100000 nM
Compound 3 was reported as a limit (the forecaster's own chance of this, stated with the estimate: 60%); middle value at least 1.4-fold (0.15 log units) away from the limit.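

In this assay compound 3 gives > 100000 nM as a limit and not a number. Among the compounds shown here, compound 2 is also reported only as a limit, so no step from compound 2 to compound 3 can be read. The compounds shown leave open whether phenyl in place of methyl changes this read-out at all, since all of them stand at the same limit: the limit of > 100000 nM in this assay, at which 3 of the 3 values shown sit.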